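Moving the methoxy group on the benzamide ring

This account rests on a few compounds, and the source may have more. Where it says the series, first, only, none or still open, it means among the compounds named here.

Of the compounds shown here, three sharing one core have been measured in an assay on MDA-MB-231 cells for binding affinity to C-X-C chemokine receptor type 4 (Homo sapiens), read by immunofluorescence and microscopy, with stated times of 10 min and 30 min; a higher number here means that more compound is needed for the effect, a lower number that less compound is needed. Compound 1 `Cc1ccc(S(=O)(=O)NCc2ccc(CNC(=O)c3ccc(F)cc3)cc2)cc1` gives 1 nM, compound 3 `COc1ccc(C(=O)NCc2ccc(CNS(=O)(=O)c3ccc(C)cc3)cc2)cc1` gives 100 nM, and compound 2 `COc1ccc(C(=O)NCc2ccc(CNS(=O)(=O)c3ccccc3)cc2)cc1` gives 1000 nM, the highest number of the three. The step from compound 2 to compound 3 a 10-fold lower number from compound 2 to compound 3 (1.00 log units; beyond the scatter) touches the sulfonamide ring; the step from compound 1 to compound 3 a 100-fold higher number from compound 1 to compound 3 (2.00 log units; beyond the scatter) touches the benzamide ring and shows that what sits on that ring can shift the number a great deal.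

Compound 4 `COc1ccccc1C(=O)NCc1ccc(CNS(=O)(=O)c2ccccc2)cc1` is not yet measured. It differs from compound 2 in one place: 2-methoxyphenyl in place of 4-methoxyphenyl on a carbonyl carbon. Going by the values given here, no measured pair shows a methoxy group moved within this ring, so the direction of the step cannot be read from the data; the large step from compound 1 to compound 3 only warns that changes on this ring can be big. The expectation for compound 4 is therefore a number close to that of compound 2, with a wide range, estimated as 1000 nM (range 150 nM to 6000 nM), a step of no change at the digits printed from compound 2 to compound 4 (within the scatter).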

Compound 4, effective concentration (reported as EC, without a stated level of effect): 1 nM
Estimate against measurement, compound 4: 1000-fold (3.00 log units) above; the whole stated range lies above it.
By their numbers in this assay, from the lowest: compounds 1 and 4 (each within the scatter of the next); then compound 3; then compound 2.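

In this assay, moving the methoxy group gives a 1000-fold lower number from compound 2 to compound 4 (3.00 log units; beyond the scatter) with no atom gained or lost, as 2-methoxyphenyl and 4-methoxyphenyl have the same atoms and the same counted features. The earlier steps shown here each replaced one group with a different one, whereas this step shows that the position of a single methoxy group on the benzamide ring can by itself change the number greatly. Nothing available explains why this position matters so much.

From the compounds shown here alone, it remains open whether an ethoxy group, a hydroxyl group or an amine in place of the methoxy group of 2-methoxyphenyl would keep the number this low. Going by these compounds, it is also open whether the methyl group on the sulfonamide ring, which lowers the number on going from compound 2 to compound 3, would do the same on compound 4.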